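The source may report more compounds than this note shows. Statements on the series, on what has been measured and on what is new or still open speak of the compounds shown alone.

Of the compounds shown here, three sharing one core have been tested in a functional assay on TK-10 cells (Homo sapiens) for inhibition, read by sulforhodamine B assay, with a stated time of 48 h; a higher number here means a weaker inhibitor of growth, a lower number a stronger inhibitor of growth. Compound 1 `COc1cc(-c2nn(-c3cccc(NC(=O)Nc4cc(C(F)(F)F)cc(C(F)(F)F)c4)c3)cc2-c2ccncc2)ccc1Cl` gives 894 nM, compound 2 `COc1cc(-c2nn(-c3cccc(NC(=O)Nc4ccc(Cl)c(Cl)c4)c3)cc2-c2ccncc2)ccc1Cl` gives 1430 nM, and compound 3 `O=C(Nc1cccc(-n2cc(-c3ccncc3)c(-c3ccc(Cl)c(O)c3)n2)c1)Nc1ccc(Cl)c(Cl)c1` gives 1910 nM. Compound 2 thus holds the second highest of the three numbers, with compound 3 and compound 1 each within the scatter of it. Among the measured compounds shown here, the only measured single-point step, a 1.3-fold higher number from compound 2 to compound 3 (0.13 log units; within the scatter), changes little. Compound 4 `COc1cc(-c2nn(-c3cccc(NC(=O)c4ccc(Cl)c(C(F)(F)F)c4)c3)cc2-c2ccncc2)ccc1Cl` differs from compound 2 by 4-chloro-3-(trifluoromethyl)phenyl in place of (3,4-dichlorophenyl)amino on a carbonyl carbon. For the measured compounds named here, no measured step covers a change of this kind, and the one step seen stays within the scatter. Expected is therefore a step of a 1.2-fold lower number from compound 2 to compound 4 (0.08 log units; within the scatter), not beyond the scatter. In this assay compound 4 is estimated at 1200 nM, within a range from 400 nM to 4000 nM.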

Compound 4, concentration for 50% growth inhibition: 20400 nM
The estimate for compound 4 lay 17-fold (1.23 log units) below the measured number; the whole stated range lies below it.
By their numbers in this assay, from the lowest: compounds 1, 2 and 3 (each within the scatter of the next, the first and the last beyond it); then compound 4.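

In this assay, among the compounds shown here, the substituent on this carbonyl carbon matters far more than the earlier compounds could show: 4-chloro-3-(trifluoromethyl)phenyl in place of (3,4-dichlorophenyl)amino gives a 14-fold higher number from compound 2 to compound 4 (1.15 log units; beyond the scatter) and so a much weaker inhibitor of growth. The change removes the amino nitrogen with its hydrogen-bond donor and also alters the groups on the aromatic ring, so the two changes cannot be separated here. Nothing available explains the loss. Still open, as far as these compounds go, is how (4-chloro-3-(trifluoromethyl)phenyl)amino on the same carbonyl carbon would compare with compound 2 and compound 4.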